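The compounds below may be only part of what the source reports. "The series", "measured", "known", "first", "only" and "open" are said of these compounds alone.

Measured compounds:
compound 1 `CC(C)(C)OC(=O)N1CCC[C@H]1C(=O)N1CCC(NS(=O)(=O)c2cc(S(=O)(=O)c3ccccc3)ccc2C(F)(F)F)CC1`, 60 nM;
compound 2 `CC(C)C(=O)N1CCC[C@H]1C(=O)N1CCC(NS(=O)(=O)c2cc(S(=O)(=O)c3ccccc3)ccc2C(F)(F)F)CC1`, 40 nM;
compound 3 `CC(C)(C)CC(=O)N1CCC[C@H]1C(=O)N1CCC(NS(=O)(=O)c2cc(S(=O)(=O)c3ccccc3)ccc2C(F)(F)F)CC1`, 20 nM.

All three were read in an assay on isolated protein for binding affinity to secreted frizzled-related protein 1 (Homo sapiens), read by fluorescence; a lower number here means a stronger inhibitor, a higher number a weaker inhibitor. Among the measured compounds shown here, compound 3 has the lowest number of the three: its step from compound 2 is a 2.0-fold lower number from compound 2 to compound 3 (0.30 log units; within the scatter), and from compound 1 it is a 3.0-fold lower number from compound 1 to compound 3 (0.48 log units; beyond the scatter), the only one of the three steps that lies beyond the scatter. The step of a 1.5-fold lower number from compound 1 to compound 2 (0.18 log units; within the scatter) is within the scatter.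

Compound 4 `CN(C)c1ccc(C(=O)N2CCC[C@H]2C(=O)N2CCC(NS(=O)(=O)c3cc(S(=O)(=O)c4ccccc4)ccc3C(F)(F)F)CC2)cc1` differs from compound 3 in one place: 4-(dimethylamino)phenyl in place of neopentyl on a carbonyl carbon. The three measured steps all change the group on this same carbonyl carbon, among tert-butoxy, isopropyl and neopentyl, and none of them moved the number by more than a modest amount. For the measured compounds named here, an aromatic group with a hydrogen-bond acceptor enters here for the first time, so no measured step tells its direction, and only a small or no step beyond the scatter is expected in this assay: a 1.3-fold higher number from compound 3 to compound 4 (0.10 log units; within the scatter).

Compound 4 is therefore estimated at 25 nM, with a range from 8 nM to 80 nM.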

Compound 4, half-maximal inhibitory concentration: 110 nM
Beside the measured number, compound 4's estimate is 4.4-fold (0.64 log units) below it; measured number above the stated range.
By their numbers in this assay, from the lowest: compounds 3, 2, 1 and 4 (each within the scatter of the next, the first and the last beyond it).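

In this assay the group on this carbonyl carbon proves able to move the number further than the three earlier groups did: 4-(dimethylamino)phenyl in place of neopentyl gives a 5.5-fold higher number from compound 3 to compound 4 (0.74 log units; beyond the scatter) and is the largest step seen at this position, while in place of isopropyl it gives a 2.8-fold higher number from compound 2 to compound 4 (0.44 log units; beyond the scatter) and also lies beyond the scatter. Against tert-butoxy the picture differs, with a 1.8-fold higher number from compound 1 to compound 4 (0.26 log units; within the scatter) as the step, so compound 4 cannot be told apart from compound 1 and the new group loses ground only against the two carbon-chain groups. Nothing measured on these compounds gives a reason for these steps.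

The compounds shown leave open whether the aromatic ring or its dimethylamino group accounts for the step, which a plain phenyl group would begin to separate. They also leave open whether a longer chain than neopentyl, or a cyclohexylmethyl group, would keep the number of compound 3.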